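A few compounds are considered here, and "the series" means these few. Any claim that something is new, unique, unknown or untested is made for them only; others in the source may bear on it.

Measured so far, in a functional assay on HeLa cells (Homo sapiens) for cytotoxicity, read by MTT assay, with a stated time of 48 h; a higher number here means a weaker inhibitor, a lower number a stronger inhibitor:
compound 1 `CCOC(=O)c1c(-c2c(Cl)c3ccccc3oc2=O)nn(-c2cccc(Cl)c2)c1C(=O)OCC` gives 40000 nM;
compound 2 `CCOC(=O)c1c(-c2cc3ccccc3oc2=O)nn(-c2cccc(C)c2)c1C(=O)OCC` gives 245000 nM;
compound 3 `CCOC(=O)c1c(-c2cc3ccccc3oc2=O)nn(-c2ccc(C)c(C)c2)c1C(=O)OCC` gives 50000 nM.

Compound 3 stands second highest of the three numbers in this assay; its nearest neighbour is compound 1, a gap within the scatter, and its furthest is compound 2, a gap beyond the scatter. Going by the values given here, the one single-place step among the measured compounds, a 4.9-fold lower number from compound 2 to compound 3 (0.69 log units; beyond the scatter), is a modest gain from adding a methyl on an aromatic carbon.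

Compound 4 `CCOC(=O)c1c(-c2cc3ccccc3oc2=O)nn(-c2cccc(Cl)c2)c1C(=O)OCC` is still to be measured. It differs from compound 3 by 3-chlorophenyl in place of 3,4-dimethylphenyl on an aromatic nitrogen. Among the compounds with values here, no measured step covers this exact swap. Compound 1 carries the same 3-chlorophenyl on the aromatic nitrogen but differs from compound 4 elsewhere, and its value sits close to that of compound 3; compound 2 carries a single methyl on that ring and sits well above both. So the expected step is small: compound 4 is estimated to land near compound 3, with the move from compound 3 to compound 4 expected at a 1.2-fold higher number from compound 3 to compound 4 (0.08 log units; within the scatter). The estimate for compound 4 is 60000 nM, with a range from 20000 nM to 200000 nM.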

Compound 4, half-maximal inhibitory concentration: 22000 nM
Compound 4: middle estimate off by 2.7-fold (0.44 log units), on the high side; the measured number falls inside the stated range.
By their numbers in this assay, from the lowest: compounds 4, 1 and 3 (each within the scatter of the next, the first and the last beyond it); then compound 2.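

In this assay the group on the aromatic nitrogen proves able to shift the number by more than the scatter: 3-chlorophenyl in place of 3,4-dimethylphenyl gives a 2.3-fold lower number from compound 3 to compound 4 (0.36 log units; beyond the scatter). A single atom swap on that same ring, chloro in place of methyl on an aromatic carbon, gives an 11-fold lower number from compound 2 to compound 4 (1.05 log units; beyond the scatter), so the ring's substituents matter a great deal, and a chloro there does at least as well as two methyls and far better than one. Hydrogen in place of chloro on an aromatic carbon of the shared core, away from this ring, gives a 1.8-fold lower number from compound 1 to compound 4 (0.26 log units; within the scatter), so that core chloro has no readable effect in this pair.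

Nothing available explains why these swaps change the number, and all of these values remain weak in absolute terms. Still open, from the compounds shown here alone, is whether a methoxy group, a bromine or a trifluoromethyl group on the phenyl ring would lower the number further, and whether a carboxylic acid or an amide could stand in place of the ethoxycarbonyl groups.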